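From methyl to sec-butyl on a saturated chain carbon

The compounds below may be only part of what the source reports. "The series", "measured", "known", "first", "only" and "open" are said of these compounds alone.

Measured so far in a functional assay on K562 cells (Homo sapiens) for cytotoxicity, read by MTT assay, with a stated time of 24 h (a lower number here means a stronger inhibitor, a higher number a weaker inhibitor), as follows
Compound 1 `COc1ccc(/C=C\c2cc(OC)c(OC)c(OC)c2)cc1NC(=O)C1=CC(C)(C)N([O])C1(C)C` gives > 100000 nM as a limit of the assay
Compound 2 `COc1ccc(/C=C\c2cc(OC)c(OC)c(OC)c2)cc1NC(=O)[C@H](C)NC(=O)OC1CC(C)(C)N([O])C(C)(C)C1` gives 1560 nM as a true number

For the measured compounds named here, compound 2 holds the only number on the scale, and its 1560 nM is the sole anchor here. Compound 3 `CC[C@H](C)[C@H](NC(=O)OC1CC(C)(C)N([O])C(C)(C)C1)C(=O)Nc1cc(/C=C\c2cc(OC)c(OC)c(OC)c2)ccc1OC` differs from it by sec-butyl in place of methyl on a saturated chain carbon bound to an amide-type nitrogen and a carbonyl carbon with sec-butyl in place of methyl on a saturated chain carbon bound to an amide-type nitrogen and a carbonyl carbon. Going by the values given here, no measured pair shows what such a change does. The expected step of a 1.2-fold higher number from compound 2 to compound 3 (0.06 log units; within the scatter) in this assay is none beyond the scatter, with no firm direction. For compound 3 the expected value is 1800 nM with an estimated range from 550 nM to 6500 nM until the measurement is known.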

Compound 3, half-maximal inhibitory concentration: 18800 nM
Compound 3: the middle estimate sits 10-fold (1.02 log units) below what was measured; the measured number lies above the stated range.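

In this assay, sec-butyl in place of methyl on the saturated chain carbon bound to an amide-type nitrogen and a carbonyl carbon brings a 12-fold higher number from compound 2 to compound 3 (1.08 log units; beyond the scatter) and so shows that this position is sensitive to the group it carries. For the compounds shown here, this is the first measured pair to show what a change at this position does. No measurement shown here explains the size of the step. From the compounds shown here alone, whether a smaller change, such as ethyl or isopropyl, would already move the number remains open. So does the effect of a benzyl group or a hydrogen atom at this carbon.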